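The source may report more compounds than this note shows. Statements on the series, on what has been measured and on what is new or still open speak of the compounds shown alone.

Compound 2 `O=C1CS/C(=N\c2csc(-c3ccccc3)c2)N1` and compound 1 `Cc1ccc(-c2cc(/N=C3/NC(=O)CS3)cs2)cc1` share one core and differ in a single place, (methyl in place of hydrogen on an aromatic carbon). In a functional assay on MCF7 cells (Homo sapiens) for cytotoxicity, read by MTT assay, with a stated time of 72 h (a higher number here means a weaker inhibitor, a lower number a stronger inhibitor), compound 2 gives > 50000 nM, which is a limit of the assay and not a number. In this assay compound 1 gives > 50000 nM, again a limit. The step that the two limits leave unreadable from compound 2 to compound 1 is therefore not readable, because the limit of > 50000 nM in this assay, at which 3 of the 3 values shown sit, holds both of its ends.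

Compound 3 `O=C1CS/C(=N\c2csc(-c3ccc(Cl)cc3)c2)N1c1ccccc1` carries a different core; how the two cores differ is not broken down here. In this assay compound 3 gives > 50000 nM, once more a limit.

Compound 4 `Cc1ccc(N2C(=O)CS/C2=N\c2csc(-c3ccc(Cl)cc3)c2)cc1` has not been measured. It differs from compound 3 by methyl in place of hydrogen on an aromatic carbon, and the place is the same, word for word, as for the change from compound 2 to compound 1, so the two changes are the same change. Since the earlier instance of this change left the step unreadable, the expectation for compound 4 rests only on all three measured compounds sitting at the limit of > 50000 nM in this assay, at which 3 of the 3 values shown sit. Compound 4 is estimated to give 60000 nM, with a range from 20000 nM to 200000 nM. The expected step that the limit leaves unreadable from compound 3 to compound 4 rests on (the limit of > 50000 nM in this assay, at which 3 of the 3 values shown sit).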

Compound 4, half-maximal inhibitory concentration: > 50000 nM
Compound 4: a limit, no number (the forecaster's own chance of this, stated with the estimate: 80%); the middle value does not contradict the limit.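

In this assay compound 4 gives > 50000 nM, which is a limit of the assay and not a number. No step from compound 3 to compound 4 can be read, because both compounds sit at the same limit: the limit of > 50000 nM in this assay, at which 4 of the 4 values shown sit.

The compounds shown leave open how large the effect of the methyl is, and whether any of the four compounds has a measurable value.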